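The compounds below may be only part of what the source reports. "The series", "measured", "known", "first", "only" and "open" are said of these compounds alone.

Compound 3 `CN(C)CCN1CCN(c2ccc(Cn3c(=O)[nH]c4c(N)nc(C(F)(F)F)cc43)cn2)CC1` sits at a limit in an in vitro ADME assay on microsomes from liver (Homo sapiens) for pharmacokinetics (a higher number here means faster removal of the compound, a lower number slower removal), rather than at a number: compound 3 gives < 8 mL.min-1.g-1. Compound 1 `Nc1nc(C(F)(F)F)cc2c1[nH]c(=O)n2Cc1ccc(NCCO)nc1` sits at the same limit, where compound 1 gives < 8 mL.min-1.g-1. Compound 2 `CN1CCN(CCN(C)c2ccc(Cn3c(=O)[nH]c4c(N)nc(C(F)(F)F)cc43)cn2)CC1` is the only one of the three with a number, as compound 2 gives 25 mL.min-1.g-1. The two readable steps run in opposite directions: an at least 3.1-fold higher number from compound 1 to compound 2 (0.49 log units; beyond the scatter), and then an at least 3.1-fold lower number from compound 2 to compound 3 (0.49 log units; beyond the scatter). The step that the two limits leave unreadable from compound 1 to compound 3 cannot be read at all, since the limit of < 8 mL.min-1.g-1 in this assay, at which 2 of the 3 values shown sit, covers both ends of it.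

Compound 4 `CN(C)CCNc1ccc(Cn2c(=O)[nH]c3c(N)nc(C(F)(F)F)cc32)cn1` differs from compound 3 in one place: (2-(dimethylamino)ethyl)amino in place of 4-(2-(dimethylamino)ethyl)piperazin-1-yl on an aromatic carbon. Going by the values given here, no measured step swaps exactly these two groups, so the expectation leans on what has been seen at this position. Compound 1, which carries an open chain ending in a hydrogen-bond donor, sat at the limit < 8 mL.min-1.g-1, while compound 2, with a longer open chain, gave 25 mL.min-1.g-1. Compound 4 is therefore expected to land close to the limit or a little above it, which corresponds to an at least 1.2-fold higher number from compound 3 to compound 4 (0.09 log units; that floor lies within the scatter). The estimate for compound 4 is 10 mL.min-1.g-1, with a range from 5 mL.min-1.g-1 to 25 mL.min-1.g-1.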

Compound 4, intrinsic clearance in microsomes in the Homo sapiens assay: 9 mL.min-1.g-1
Compound 4: the middle estimate sits 1.1-fold (0.05 log units) above what was measured; the range from low to high includes it.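

In the Homo sapiens assay, putting (2-(dimethylamino)ethyl)amino in place of methyl(2-(4-methylpiperazin-1-yl)ethyl)amino gives a 2.8-fold lower number from compound 2 to compound 4 (0.44 log units; beyond the scatter), so an open chain on this aromatic carbon does not by itself bring a high number. In the Homo sapiens assay the other two changes give only a floor, an at least 1.1-fold higher number from compound 3 to compound 4 (0.05 log units; that floor lies within the scatter) and an at least 1.1-fold higher number from compound 1 to compound 4 (0.05 log units; that floor lies within the scatter), and their true sizes cannot be read because compound 1 and compound 3 each stand at a limit rather than at a number: the limit of < 8 mL.min-1.g-1 in the Homo sapiens assay, at which 2 of the 4 values shown sit. In a physicochemical assay for lipophilicity (on this read-out higher numbers stand for higher lipophilicity and lower numbers for lower lipophilicity), compound 3 gives 0.9 and compound 4 gives 0.7, two values within the scatter of each other, so removing the piperazine ring brings no readable change on this read-out.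

From the compounds shown here alone, the real size of the gap between compound 3 and compound 4 in the Homo sapiens assay stays open. The compounds shown also leave open how a pyrrolidine ring or a primary amine in place of the dimethylamino group would read in the Homo sapiens assay.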